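Swapping a Propyl for an Ethylcarbamoyl Group

This account rests on a few compounds, and the source may have more. Where it says the series, first, only, none or still open, it means among the compounds named here.

Measured compounds:
compound 1 `CCC[C@@H]1CN[C@H](C(=O)N2CCC[C@H]2C#N)C1`: 50%
compound 2 `CCN(C)C(=O)[C@H]1C[C@@H](C(=O)N2CCC[C@H]2C#N)N[C@H]1C`: 92%
compound 3 `C[C@@H]1N[C@H](C(=O)N2CCC[C@H]2C#N)C[C@@H]1C(=O)N1CCSCC1`: 92%

In an assay on the whole organism (plasma, strain Sprague-Dawley) for inhibition of Dipeptidyl peptidase 4 (Rattus norvegicus), with a stated time of 6 h, at a dose of 1 mg/kg by the oral route (on this read-out lower numbers stand for less inhibition and higher numbers for more inhibition at the one dose given (going by the name of the read-out)), compound 1 stands lowest of the three, with compound 2 and compound 3 both beyond the scatter above it. Among the measured compounds shown here, the only measured single step, no change at the digits printed from compound 2 to compound 3 (within the scatter), concerns a group on a carbonyl carbon and so does not bear on the change studied here.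

Compound 4 `CCNC(=O)[C@@H]1CN[C@H](C(=O)N2CCC[C@H]2C#N)C1` differs from compound 1 by ethylcarbamoyl in place of propyl on a saturated ring carbon. Compound 2 and compound 3, which also carry an amide, sit above compound 1, but they differ from it in more than one place, so they give only a hint. A moderate rise is expected, a number 15 percentage points higher from compound 1 to compound 4 (beyond the scatter). Compound 4 is estimated at 65%, in the range 40% to 88%.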

Compound 4, a percentage reported as inhibition, in the whole organism at one dose (the size of the read-out at that dose, not a potency): 60%
Beside the measured number, compound 4's estimate is 5 percentage points above it; measured number inside the range.
By their numbers in this assay, from the lowest: compounds 1 and 4 (each within the scatter of the next); then compounds 2 and 3 (each within the scatter of the next).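

Among the compounds shown here, compound 4 is the first compound here that differs from compound 1 only in the group on the saturated ring carbon, so it allows a direct comparison at this position. In this assay, ethylcarbamoyl in place of propyl gives a number 10 percentage points higher from compound 1 to compound 4 (within the scatter), so this exchange of groups cannot be told apart from repeat scatter at the single dose tested. No supporting measurement bears on this result.

As far as these compounds go, it remains open how an amine, a carboxylic acid or a longer chain on this ring carbon would read in the same test.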